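Notes: butyl to cyclopentyl on the aromatic nitrogen

The source may hold more compounds than are shown below. What is called first, only, known or untested is meant among the compounds shown, and "the series" means these compounds.

Of the compounds shown here, three have been measured in a functional assay on NCI-H460 cells (Homo sapiens) for antiproliferative activity, read by CCK-8 assay, with a stated time of 72 h, tested at 2 uM; a lower number here means a weaker effect, a higher number a stronger effect of the compound at the concentration tested. Compound 1 `CC(C)n1cnc2c(Nc3cccc(Cl)c3)nc(NCOCc3ccc(C(=O)Nc4ccccc4N)cc3)nc21` gives 28.9%. Compound 2 `Nc1ccccc1NC(=O)c1ccc(COCNc2nc(Nc3ccc(-c4ccccc4)cc3)c3ncn(C4CCCC4)c3n2)cc1` gives 33.5%. Compound 3 `CCCCn1cnc2c(Nc3cccc(Cl)c3)nc(NCOCc3ccc(C(=O)Nc4ccccc4N)cc3)nc21` gives 56.9% and stands highest of the three, ahead of compound 2 by a margin beyond the scatter and further ahead of compound 1. For the measured compounds named here, the only step between compounds that differ in a single place is a number 28 percentage points higher from compound 1 to compound 3 (beyond the scatter), a modest gain from a larger group on the aromatic nitrogen.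

Compound 4 `Nc1ccccc1NC(=O)c1ccc(COCNc2nc(Nc3cccc(Cl)c3)c3ncn(C4CCCC4)c3n2)cc1` has not yet been measured. It differs from compound 3 in one place: cyclopentyl in place of butyl on an aromatic nitrogen. Going by the values given here, no measured step covers exactly this exchange. The step from compound 1 to compound 3 shows that this position responds to what is attached, and its size sets the scale of what might happen. Compound 2 also carries cyclopentyl on the aromatic nitrogen but differs from compound 3 in a second place as well, so compound 2 with its 33.5% only hints that cyclopentyl does not by itself carry a number as high as that of compound 3. The expected step is a number 11.9 percentage points lower from compound 3 to compound 4 (beyond the scatter), a modest drop that is not certain. Compound 4 is estimated at 45% in this assay, with a range from 25% to 65%.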

Compound 4, a percentage reported as inhibition, at one concentration (the size of the read-out at that concentration, not a potency): 36.1%
Compound 4: the middle estimate sits 8.9 percentage points above what was measured, and the stated range covers the measured number.
By their numbers in this assay, from the lowest: compounds 1, 2 and 4 (each within the scatter of the next); then compound 3.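

In this assay, cyclopentyl in place of butyl on the aromatic nitrogen gives a number 20.8 percentage points lower from compound 3 to compound 4 (beyond the scatter), so the number does not simply follow the heavy-atom count: cyclopentyl has 5 heavy atoms and butyl 4, and the ring-bearing compound falls short. Cyclopentyl in place of isopropyl gives a number 7.2 percentage points higher from compound 1 to compound 4 (within the scatter), so these two groups do not separate here, and among the three groups at this position with 3-chlorophenyl kept constant, only butyl stands apart. With cyclopentyl held constant, 3-chlorophenyl in place of 4-phenylphenyl gives a number 2.6 percentage points higher from compound 2 to compound 4 (within the scatter), so at this level the two aryl groups do not separate.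

Nothing available on these compounds accounts for the position of butyl relative to the other two groups. On these data alone, whether the higher number belongs to an unbranched chain in general stays open, and a propyl, pentyl or hexyl chain on this nitrogen, set against a cyclobutyl ring, would test that.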